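A few compounds are considered here, and "the series" means these few. Any claim that something is new, unique, unknown or untested is made for them only; others in the source may bear on it.

Compound 1 `O=C(Nc1cc(C(F)(F)F)cc(C(F)(F)F)c1)c1ccccc1O` gives 12000 nM in an ADME assay on cells (Macrophage, Mus musculus) for cytotoxicity, read by resazurin assay, with a stated time of 3 days; on this read-out higher numbers stand for weaker inhibition and lower numbers for stronger inhibition. Compound 3 `COc1ccc(O)c(C(=O)Nc2cc(C(F)(F)F)cc(C(F)(F)F)c2)c1` differs from compound 1 by methoxy in place of hydrogen on an aromatic carbon, and in this assay compound 3 gives 7700 nM, the step of a 1.6-fold lower number from compound 1 to compound 3 (0.19 log units; within the scatter). Compound 2 `O=C(Nc1cc(C(F)(F)F)cc(C(F)(F)F)c1)c1cccc(Cl)c1` carries a different core, set apart from compound 1 by 3-chlorophenyl in place of 2-hydroxyphenyl on a carbonyl carbon, with the step of an at least 5.0-fold higher number from compound 1 to compound 2 (0.69 log units; beyond the scatter). For compound 2 this assay reports only a limit of the assay and not a number, > 60000 nM, as the limit of > 60000 nM in this assay, at which 1 of the 3 values shown sits, shows. Compound 4 `COc1ccc(Cl)cc1C(=O)Nc1cc(C(F)(F)F)cc(C(F)(F)F)c1` is not yet measured in this assay. It differs from compound 2 by methoxy in place of hydrogen on an aromatic carbon, the same kind of change as that from compound 1 to compound 3, though there the place was meta to a large group and para to a hydroxy group, whereas here it is ortho to a large group and para to a chloro group. Beside the earlier 1.6-fold lower number from compound 1 to compound 3 (0.19 log units; within the scatter), the step expected from compound 2 to compound 4 is a number no higher from compound 2 to compound 4 (the limit leaves the size open), resting on that step being within the scatter. Compound 4 is therefore expected to give about 60000 nM, between 25000 nM and 150000 nM.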

Compound 4, half-maximal inhibitory concentration: > 60000 nM
Compound 4 was reported as a limit; the forecaster's own chance of this, stated with the estimate: 65%; the middle value sits exactly at the limit.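

Compound 2 and compound 4 are both reported only as a limit in this assay, so no step between them can be read: the limit of > 60000 nM in this assay, at which 2 of the 4 values shown sit.

The compounds shown leave open what methoxy in place of hydrogen does here to the half-maximal inhibitory concentration.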